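Bromo in Place of Chloro: an Expectation for Compound 3

The source may report more compounds than this note shows. Statements on the series, on what has been measured and on what is new or still open speak of the compounds shown alone.

Compound 1 `O=C1C(CO)=C[C@@H](O)[C@@H](O)[C@@H]1Br` gives 9700 nM in a functional assay on MCF7 cells (Homo sapiens) for cytotoxicity, read by sulforhodamine B assay, with a stated time of 3 days; on this read-out higher numbers stand for weaker inhibition and lower numbers for stronger inhibition.
Compound 2 `O=C1C(CO)=C[C@@H](O)[C@@H](O)[C@H]1Cl` gives > 20000 nM in this assay, a limit of the measurement and not a number.

Among the compounds with values here, only two compounds have been measured, and no step between them is recorded. Compound 2 stands at the limit of this assay, so its position relative to compound 1 cannot be read from the numbers; the one thing shown is that its value is a limit (the limit of > 20000 nM in this assay, at which 1 of the 2 values shown sits).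

Compound 3 `O=C1C(CO)=C[C@@H](O)[C@@H](O)[C@H]1Br` is not yet measured. It differs from compound 2 by bromo in place of chloro on a saturated ring carbon. Within the data shown here, with no measured step to draw on, the change from chloro to bromo is expected to move the result little, if at all, beyond the usual scatter of this assay; the estimate corresponds to an at least 1.3-fold lower number from compound 2 to compound 3 (0.12 log units; that floor lies within the scatter). Compound 3 is therefore expected to give about 15000 nM, with a plausible range from 5000 nM to 45000 nM, and a real chance that it too is reported only as a limit.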

Compound 3, half-maximal inhibitory concentration: 9700 nM
For compound 3 the middle estimate is 1.5-fold (0.19 log units) above the measured one, and the stated range covers the measured number.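

On this saturated ring carbon, bromo in place of chloro gives a change that can be read in this assay: an at least 2.0-fold lower number from compound 2 to compound 3 (0.31 log units; beyond the scatter). Compound 2 sits at a limit, so this step has a floor and its full size cannot be told: the limit of > 20000 nM in this assay, at which 1 of the 3 values shown sits.

The configuration at the bromo-bearing carbon gives no change at the digits printed from compound 1 to compound 3 (within the scatter), so with bromo in place, this read-out does not separate the two drawn forms: the fact that compounds 1 and 3 differ only in the configuration as drawn

It remains open whether the drawn configuration at this carbon would matter with chloro there, since the compounds shown pair the two forms only with bromo. They also leave open how an amine or an iodo group on this carbon would compare with bromo.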